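The compounds below may be only part of what the source reports. "The series", "measured", "known", "first", "only" and "open" are said of these compounds alone.

In a functional assay on HCT-116 cells (Homo sapiens) for cytotoxicity, read by MTT assay, with a stated time of 72 h (on this read-out higher numbers stand for weaker inhibition and lower numbers for stronger inhibition), compound 1 `CN(C)CCCCCn1c2c(c3ccccc31)C(=O)c1c[n+]([O-])c3ccccc3c1C2=O` gives 470 nM and compound 2 `O=C1c2c[n+]([O-])c3ccccc3c2C(=O)c2c1c1ccccc1n2CCCCN1CCCCC1` gives 200 nM, the lower of the two numbers. Compound 3 `O=C1c2c[n+]([O-])c3ccccc3c2C(=O)c2c1c1ccccc1n2CCN1CCCCC1` differs from compound 2 by piperidin-1-yl in place of 2-(piperidin-1-yl)ethyl on a saturated chain carbon, two bonds along the chain from an aromatic nitrogen: piperidin-1-yl in place of 2-(piperidin-1-yl)ethyl, two bonds along the chain from an aromatic nitrogen. Among the measured compounds shown here, the only measured step, a 2.4-fold lower number from compound 1 to compound 2 (0.37 log units; beyond the scatter), is modest and lies four bonds along the chain, with a different group leaving, so it bears only loosely on this change. In this assay the expected step, a 1.3-fold higher number from compound 2 to compound 3 (0.10 log units; within the scatter), is no larger than that one and has no firm direction. For compound 3 the estimate is 250 nM, with an expected range of 80 nM to 800 nM.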

Compound 3, half-maximal inhibitory concentration: 780 nM
Estimate against measurement, compound 3: 3.1-fold (0.49 log units) below; the measured number falls inside the stated range.
By their numbers in this assay, from the lowest: compound 2; then compounds 1 and 3 (each within the scatter of the next).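

In this assay, with the piperidine held fixed, 2-(piperidin-1-yl)ethyl in place of 4-(piperidin-1-yl)butyl gives a 3.9-fold higher number from compound 2 to compound 3 (0.59 log units; beyond the scatter), so chain length at this position changes the result, which the earlier pair could not show. The other new step, a 1.7-fold higher number from compound 1 to compound 3 (0.22 log units; within the scatter), lies within the scatter, so these two chain and amine combinations are not told apart. Nothing available explains the effect of chain length.

Going by these compounds, how 3-(piperidin-1-yl)propyl or a longer chain such as 5-(piperidin-1-yl)pentyl would fit remains open. So does whether morpholine at the chain end would follow piperidine.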